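The compounds below may be only part of what the source reports. "The series", "measured", "known", "first", "only" and "open" are said of these compounds alone.

Compound 2 `CN1CCc2nc(C#Cc3ccccc3)sc2C1` sits at the limit of an assay on HEK293 cells for negative allosteric modulation of metabotropic glutamate receptor 5 (Homo sapiens), read by FLIPR, with a stated time of 1 h; on this read-out higher numbers stand for weaker inhibition and lower numbers for stronger inhibition: in this assay compound 2 gives > 10000 nM, which is a limit of the assay rather than a number. Compound 1 `O=C1NCCc2nc(C#Cc3ccccc3)sc21` gives > 10000 nM in this assay, again a limit. Compound 3 `CN1CCc2nc(C#Cc3cccc(F)c3)sc2C1` gives > 10000 nM in this assay, also a limit. Within the data shown here, the only measured step, a step that the two limits leave unreadable from compound 2 to compound 3, is therefore unreadable, as all values sit at the limit of > 10000 nM in this assay, at which 3 of the 3 values shown sit. Compound 4 `CCN1CCc2nc(C#Cc3ccccc3)sc2C1` differs from compound 2 by methyl in place of hydrogen on a saturated chain carbon bound to an amine nitrogen in a ring. No readable step bears on this change, so no direction can be expected. Compound 4 is expected to give about 20000 nM, with a range from 5000 nM to 80000 nM. That estimate corresponds to an expected step that the limit leaves unreadable from compound 2 to compound 4.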

Compound 4, half-maximal inhibitory concentration: 1200 nM
Compound 4: the middle estimate sits 17-fold (1.22 log units) above what was measured; the whole stated range lies above it.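

Methyl in place of hydrogen on a saturated chain carbon bound to an amine nitrogen in a ring gives an at least 8.3-fold lower number from compound 2 to compound 4 (0.92 log units; beyond the scatter) in this assay, and on this read-out a lower number means stronger inhibition. This position therefore responds to a very small change, methyl to ethyl, which brings the compound within the measurable range. Compound 4 is the only compound shown with a number rather than a limit: the limit of > 10000 nM in this assay, at which 3 of the 4 values shown sit.

As far as these compounds go, whether a longer chain, such as propyl, or a branched group, such as isopropyl, lowers the number further remains open. Also open, from the compounds shown here alone, is whether the fluoro group of compound 3 would change the value of compound 4.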